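Isopropyl to Hexyl on Two Related Cores

A few compounds are considered here, and "the series" means these few. Any claim that something is new, unique, unknown or untested is made for them only; others in the source may bear on it.

Compound 1, `Cc1ccc(S(=O)(=O)N2CC[C@@H](Cl)C[C@@H]2CC(C)C)cc1`, gives 36000 nM in a functional assay on A2780 cells (Homo sapiens) for antiproliferative activity, read by sulforhodamine B assay, with a stated time of 48 h; on this read-out higher numbers stand for weaker inhibition of growth and lower numbers for stronger inhibition of growth.
Compound 2, `CCCCCCC[C@H]1C[C@H](Cl)CCN1S(=O)(=O)c1ccc(C)cc1`, reaches only the limit > 100000 nM in this assay.
Compound 3, `Cc1ccc(S(=O)(=O)N2CCC(Br)=CC2CC(C)C)cc1`, gives 36000 nM in this assay.

Compound 2 differs from compound 1 by hexyl in place of isopropyl on a saturated chain carbon bound to a saturated ring carbon. That change brought an at least 2.7-fold higher number from compound 1 to compound 2 (0.44 log units; beyond the scatter), the value of compound 2 sitting at the limit of > 100000 nM in this assay, at which 1 of the 3 values shown sits. The difference between the core of compound 3 and the core of compound 1 is not broken down here; their values in this assay sit within the scatter of each other. Compound 4, `CCCCCCCC1C=C(Br)CCN1S(=O)(=O)c1ccc(C)cc1`, differs from compound 3 by hexyl in place of isopropyl on a saturated chain carbon bound to a saturated ring carbon, the same change at the same place. The step is expected to be a 3.1-fold higher number from compound 3 to compound 4 (0.49 log units; beyond the scatter), at least modest, because an at least 2.7-fold higher number from compound 1 to compound 2 (0.44 log units; beyond the scatter). Compound 4 is estimated at 110000 nM, likely between 50000 nM and 300000 nM.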

Compound 4, concentration for 50% growth inhibition: > 100000 nM
Compound 4: no number, only a limit (the forecaster's own chance of this, stated with the estimate: 60%); the middle value does not contradict the limit.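

In this assay compound 4 gives > 100000 nM, which is a limit of the assay and not a number. Hexyl in place of isopropyl brought an at least 2.7-fold higher number from compound 3 to compound 4 (0.44 log units; beyond the scatter), so the direction of the change carries over from one core to the other: the same change on two cores in this assay, an at least 2.7-fold higher number (0.44 log units; beyond the scatter) from compound 1 to compound 2 and an at least 2.7-fold higher number (0.44 log units; beyond the scatter) from compound 3 to compound 4; the limit leaves it open whether they differ. As far as these compounds go, the true size of the step on either core stays unknown, since compound 2 and compound 4 both rest at the limit: the limit of > 100000 nM in this assay, at which 2 of the 4 values shown sit.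

The compounds shown leave open how a chain of intermediate length, such as butyl, would read on these cores. They also leave open whether a chain ending in an amine or a carboxylic acid would read differently from hexyl.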